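Methyl for methoxy on the aryl ring of a dienone series

This account rests on a few compounds, and the source may have more. Where it says the series, first, only, none or still open, it means among the compounds named here.

Two dienones sharing one core have been measured. Compound 1 `CC1=C(/C=C/C(=O)/C=C/c2ccc(Cl)cc2)C(C)(C)CCC1` carries a chlorine on its aromatic ring, and in a functional assay on PC-3 cells (Homo sapiens) for cytotoxicity, read by sulforhodamine B assay, with a stated time of 48 h (on this read-out higher numbers stand for weaker inhibition and lower numbers for stronger inhibition), compound 1 gives 9500 nM. Compound 2 `COc1ccccc1/C=C/C(=O)/C=C/C1=C(C)CCCC1(C)C` carries a methoxy group instead, and in this assay compound 2 gives 14200 nM. Of the two numbers, that of compound 2 is the higher one, but its gap to compound 1 is within the scatter, so the two compounds cannot be told apart on these data.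

Compound 3 `CC1=C(/C=C/C(=O)/C=C/c2ccccc2C)C(C)(C)CCC1` has not yet been tested. It differs from compound 2 by methyl in place of methoxy on an aromatic carbon. For the measured compounds named here, no measured pair shows what such a change does here, and the two values at hand sit close together, so the expectation is a step of no size beyond the scatter, in neither direction. On that basis compound 3 is expected to give about 12000 nM in this assay, within a range from 5000 nM to 30000 nM, which would mean a step of a 1.2-fold lower number from compound 2 to compound 3 (0.07 log units; within the scatter) that is expected to stay within the scatter.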

Compound 3, half-maximal inhibitory concentration: 44100 nM
Estimate against measurement, compound 3: 3.7-fold (0.57 log units) below; the measured number lies above the stated range.
By their numbers in this assay, from the lowest: compounds 1 and 2 (each within the scatter of the next); then compound 3.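

For the compounds shown here, compound 3 gives the first step beyond the scatter in this short series: in this assay the exchange of methoxy for methyl on an aromatic carbon, ortho to a large group, produces a 3.1-fold higher number from compound 2 to compound 3 (0.49 log units; beyond the scatter) and so shows that this place on the ring does not tolerate every small group equally. The exchange of 4-chlorophenyl for 2-methylphenyl points the same way, with a 4.6-fold higher number from compound 1 to compound 3 (0.67 log units; beyond the scatter) on the same read-out, so compound 3 stands apart from both earlier compounds, which themselves could not be told apart. Nothing at hand accounts for why methyl weakens the inhibition here, and the size of the step remains an observation without an explanation.

The compounds shown leave open whether a hydroxy group, an amine or a longer alkoxy chain at this same place would give a number nearer that of compound 2 or that of compound 3. They also leave open whether methyl would give a similar step on the ring carbon that carries the chlorine in compound 1.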